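Swapping a sulfur link for an amine link in a quinoxaline pair

The source may report more compounds than this note shows. Statements on the series, on what has been measured and on what is new or still open speak of the compounds shown alone.

Compound 1 `CCOC(=O)[C@H](CCC(=O)O)NC(=O)c1ccc(Sc2nc3cc(N)cc(N)c3nc2-c2ccccc2)cc1`: < 100000 nM
Compound 2 `Nc1cc(N)c2nc(-c3ccccc3)c(Sc3ccc(F)cc3)nc2c1`: 34700 nM

In a functional assay on NCI/ADR-RES cells (Homo sapiens) for inhibition, read by sulforhodamine B assay, with a stated time of 48 h (a higher number here means a weaker inhibitor of growth, a lower number a stronger inhibitor of growth), compound 1 reaches only (the limit of < 100000 nM in this assay, at which 1 of the 2 values shown sits), which is a limit, not a number. Compound 2 holds the only measured number shown, at 34700 nM. Compound 3 `Nc1cc(N)c2nc(-c3ccccc3)c(NCc3ccc(F)cc3)nc2c1` differs from compound 2 in one spot: (4-fluorobenzyl)amino in place of (4-fluorophenyl)sulfanyl on an aromatic carbon. Within the data shown here, with no measured step of this kind to lean on, the change is expected to move growth inhibition little, if at all, in either direction beyond the usual scatter. Compound 3 is therefore estimated at 30000 nM in this assay, between 8000 nM and 100000 nM, a step of a 1.2-fold lower number from compound 2 to compound 3 (0.06 log units; within the scatter).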

Compound 3, concentration for total growth inhibition: 5750 nM
Estimate against measurement, compound 3: 5.2-fold (0.72 log units) above, and the stated range ends above it.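

In this assay, the group at this position on the shared core matters: (4-fluorobenzyl)amino in place of (4-fluorophenyl)sulfanyl gives a 6.0-fold lower number from compound 2 to compound 3 (0.78 log units; beyond the scatter). Among these compounds, this is the first measured step at this position, and it shows that growth inhibition responds to this change. Nothing measured here explains the size of this step.

The swap alters the linking atom and adds a carbon at the same time, so the two effects remain unseparated. A (4-fluorophenyl)amino group or a (4-fluorobenzyl)sulfanyl group would tell them apart.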